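The source may report more compounds than this note shows. Statements on the series, on what has been measured and on what is new or still open speak of the compounds shown alone.

Measured compounds:
- compound 1 `Cc1c(OCCCCOc2ccc(C(=O)O)cc2)ccc(C(=O)CC2CCCC2)c1O`: > 10000 nM
- compound 2 `Cc1cc(C(=O)O)ccc1OCCCCOc1ccc(C(=O)CC(C)C)c(O)c1C`: 1850 nM
- compound 3 `Cc1c(OCCCCOc2ccccc2C(=O)O)ccc(C(=O)CC2CCCC2)c1C`: "not determined" (no result reported)

Going by the values given here, in an assay on HEK293 cells for positive allosteric modulation of metabotropic glutamate receptor 3 (Rattus norvegicus), read by thallium flux, with a stated time of 2.5 min (on this read-out lower numbers stand for an effect already at smaller amounts and higher numbers for an effect only at larger amounts of compound), compound 1 gives only a limit, > 10000 nM, and not a number; it is the one value of the three that sits at the limit of > 10000 nM in this assay, at which 1 of the 3 values shown sits. Compound 2, which shares the linker and the carboxyphenyl end, gives 1850 nM in this assay. Compound 3 gives "not determined" (no result reported) in this assay, so nothing can be said of it here. Among the compounds with values here, compound 1 is therefore the weaker of the two compounds with a number or a limit, and no step between measured compounds is available to guide what follows.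

Compound 4 `Cc1c(OCCCCOCOc2ccc(C(=O)O)cc2)ccc(C(=O)CC2CCCC2)c1O` differs from compound 1 by (4-carboxyphenoxy)methyl in place of 4-carboxyphenyl on an oxygen on a saturated carbon. Because compound 1 already sits at the limit of > 10000 nM in this assay, at which 1 of the 3 values shown sits, the step from compound 1 to compound 4 is expected to be none beyond the scatter, and most likely compound 4 will again return only a limit in this assay. The estimate for compound 4 is 25000 nM, within 6000 nM to 100000 nM, which corresponds to an expected step that the limit leaves unreadable from compound 1 to compound 4.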

Compound 4, half-maximal effective concentration: 1910 nM
For compound 4 the middle estimate is 13-fold (1.12 log units) above the measured one; the measured number lies below the stated range.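

In this assay, (4-carboxyphenoxy)methyl in place of 4-carboxyphenyl on an oxygen on a saturated carbon gives an at least 5.2-fold lower number from compound 1 to compound 4 (0.71 log units; beyond the scatter). The earlier compounds shown here offered no step at all, and this one shows that a change in this place alone, with the rest of the core of compound 1 kept, is enough to turn a limit into a measured number. The true size of the step stays unread, as its starting point is a limit and not a number: the limit of > 10000 nM in this assay, at which 1 of the 4 values shown sits.

This single step cannot separate the contribution of the added oxygen from that of the added carbon in (4-carboxyphenoxy)methyl. The compounds shown also leave open how this place would respond to an all-carbon chain of the same length, or to a tetrazole in place of the carboxylic acid.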